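A few compounds are considered here, and "the series" means these few. Any claim that something is new, unique, unknown or untested is made for them only; others in the source may bear on it.

Measured compounds:
- compound 1, `COc1ccc(-c2cc(C(=O)/C=C/c3ccccc3)nc3cc(-c4ccccc4)nn23)cc1OC`, 64100 nM
- compound 2, `COc1ccc(C(=O)/C=C/c2cc(-c3cc(OC)c(OC)c(OC)c3)n3nc(-c4ccccc4)cc3n2)cc1`, 79800 nM

In an ADME assay on HEK293 cells (Homo sapiens) for antiproliferative activity, read by MTT assay, with a stated time of 24 h (on this read-out higher numbers stand for weaker inhibition and lower numbers for stronger inhibition), compound 1 gives 64100 nM. In this assay compound 2 gives 79800 nM. Only these two values are known, and the gap between compound 2 and compound 1 is within the scatter, so neither can be set apart from the other on this read-out.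

Compound 3, `COc1cc(C(=O)/C=C/c2cc(-c3cc(OC)c(OC)c(OC)c3)n3nc(-c4ccccc4)cc3n2)cc(OC)c1OC`, has not been measured. It differs from compound 2 in one place: 3,4,5-trimethoxyphenyl in place of 4-methoxyphenyl on a carbonyl carbon. Among the compounds with values here, no measured pair shows the effect of this change, so nothing in the data points to a step in either direction. The expectation for compound 3 is therefore a step of a 1.1-fold lower number from compound 2 to compound 3 (0.04 log units; within the scatter), that is, none beyond the scatter. Compound 3 is accordingly estimated at 72000 nM, within a range of 30000 nM to 160000 nM.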

Compound 3, half-maximal inhibitory concentration: >= 100000 nM
Compound 3 ended at the assay's limit; the forecaster's own chance of this, stated with the estimate: 20%; middle value at least 1.3-fold (0.14 log units) from the limit.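

In this assay compound 3 gives >= 100000 nM, which is a limit of the assay and not a number. Placing 3,4,5-trimethoxyphenyl in place of 4-methoxyphenyl on a carbonyl carbon, a change no earlier pair had covered, gives an at least 1.2-fold higher number from compound 2 to compound 3 (0.09 log units; that floor lies within the scatter), so the data offer no sign that the two extra methoxy groups bring stronger inhibition. Only the floor of this step can be read, and its true size remains unknown: the limit of >= 100000 nM in this assay, at which 1 of the 3 values shown sits.

What the compounds shown leave open is how a phenyl ring carrying an amine or a carboxylic acid would read on this carbonyl carbon. They also leave open whether this change would give the same result with another group elsewhere on the shared core.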